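The compounds below may be only part of what the source reports. "The series", "measured", "known", "first", "only" and "open" are said of these compounds alone.

Two measured compounds share one core and differ in a single outer part. Compound 1 `COc1cc(C(=O)Nc2ccc(C(=O)/C=C/c3nc(C)c(C)nc3C)cc2)cc(OC)c1OC` carries methoxy groups there; in a functional assay on A549 cells (Homo sapiens) for antiproliferative activity, read by CCK-8 assay, with a stated time of 72 h (a higher number here means a weaker inhibitor, a lower number a stronger inhibitor), compound 1 gives 7350 nM. Compound 2 `Cc1nc(C)c(/C=C/C(=O)c2ccc(NC(=O)c3ccc(F)cc3)cc2)nc1C` carries fluoro instead; in this assay compound 2 gives 4480 nM. Of the two numbers that of compound 2 is the lower, but the gap to compound 1 lies within the usual scatter of repeated measurements, so neither compound can be called the stronger inhibitor. Compound 3 `COc1ccc(C(=O)Nc2ccc(C(=O)/C=C/c3nc(C)c(C)nc3C)cc2)cc1` is not yet measured. It differs from compound 2 by methoxy in place of fluoro on an aromatic carbon. Among the measured compounds shown here, no step between measured compounds matches this change, so the expectation rests only on compound 1 and compound 2 lying close together. The step of a 1.2-fold higher number from compound 2 to compound 3 (0.09 log units; within the scatter) is expected to be small, at most a slight move toward a higher number. Compound 3 is therefore estimated at 5500 nM in this assay, with a range from 2500 nM to 12000 nM.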

Compound 3, half-maximal inhibitory concentration: 4150 nM
Beside the measured number, compound 3's estimate is 1.3-fold (0.12 log units) above it, within the range that was stated.
By their numbers in this assay, from the lowest: compounds 3, 2 and 1 (each within the scatter of the next).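

Replacing fluoro with methoxy on this aromatic carbon, para to a large group, gives a 1.1-fold lower number from compound 2 to compound 3 (0.03 log units; within the scatter) in this assay. Among the compounds shown here, this is the first direct comparison of a single change at this position, and 4-fluorophenyl and 4-methoxyphenyl cannot be told apart here, even though the change adds a heavy atom and a hydrogen-bond acceptor. Nothing available explains why the two compounds read alike.

From the compounds shown here alone, it remains open whether this position would respond to a different kind of group, such as an amine, a carboxylic acid or a longer chain. A single pair also cannot show whether methoxy in place of fluoro would read the same way on a different core.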